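A Fluoro Substituent Added to the Ecdysone Agonist Scaffold

The source may hold more compounds than are shown below. What is called first, only, known or untested is meant among the compounds shown, and "the series" means these compounds.

Compound 1 `CC(C)(C)N(NC(=O)c1ccccc1)C(=O)c1ccccc1Cl`: 75.9 nM
Compound 2 `CC(C)(C)N(NC(=O)c1ccccc1)C(=O)c1ccccc1C(F)(F)F`: 631 nM
Compound 3 `Cc1cc(C)cc(C(=O)N(NC(=O)c2ccccc2)C(C)(C)C)c1`: 69.2 nM

In an assay on cells for agonist activity at ecdysone receptor (Bombyx mori), read by a luciferase reporter, with a stated time of 24 h (on this read-out higher numbers stand for an effect only at larger amounts of compound and lower numbers for an effect already at smaller amounts), compound 1 stands second highest of the three numbers. The step of a 1.1-fold lower number from compound 1 to compound 3 (0.04 log units; within the scatter) stays within the scatter, whereas the step of an 8.3-fold higher number from compound 1 to compound 2 (0.92 log units; beyond the scatter) lies beyond it. Compound 4 `CC(C)(C)N(NC(=O)c1ccccc1F)C(=O)c1ccccc1Cl` differs from compound 1 by fluoro in place of hydrogen on an aromatic carbon, on an aromatic carbon of a six-membered aromatic ring of carbon only, ortho to a large group. Neither measured step touches this ring; both alter the ring attached to the other carbonyl of the shared core, so they bear only loosely on the change. Compound 4 is therefore expected to show a step of a 1.0-fold lower number from compound 1 to compound 4 (0.01 log units; within the scatter) that stays within the scatter. The estimate for compound 4 is 75 nM, ranging from 30 nM to 200 nM.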

Compound 4, half-maximal effective concentration: 51.3 nM
Compound 4: middle estimate off by 1.5-fold (0.16 log units), on the high side, and the stated range covers the measured number.
By their numbers in this assay, from the lowest: compounds 4, 3 and 1 (each within the scatter of the next); then compound 2.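

In this assay, fluoro in place of hydrogen, ortho to a large group, gives a 1.5-fold lower number from compound 1 to compound 4 (0.17 log units; within the scatter) and so leaves the two compounds unseparated. This is the first change shown on this ring, as the earlier steps altered only the ring on the other carbonyl. No available evidence bears on this result. The compounds shown leave open whether a methoxy group or an amine in this same place would read like fluoro. They also leave open whether the phenyl to 2-fluorophenyl change would read the same alongside the 3,5-dimethylphenyl of compound 3.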